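This account rests on a few compounds, and the source may have more. Where it says the series, first, only, none or still open, it means among the compounds named here.

Compound 3 `Cc1cc(-c2nc3ccccc3o2)ccc1NC(=O)CN1CCN(CCN(C)C)CC1` gives 12900 nM in a functional assay on HT-29 cells (Homo sapiens) for cytotoxicity, read by MTT assay, with a stated time of 24 h (a higher number here means a weaker inhibitor, a lower number a stronger inhibitor), the highest of the three numbers in hand. Compound 2 `CN(C)CCCN1CCN(CC(=O)Nc2ccc(-c3nc4ccccc4o3)cc2)CC1` gives 10600 nM, a number within the scatter of compound 3, so the two are not told apart. Compound 1 `Cc1ccc2oc(-c3ccc(NC(=O)CN4CCN(CCN(C)C)CC4)cc3)nc2c1` gives 1790 nM, a gap to compound 3 that lies beyond the scatter. Among the measured compounds shown here, compound 1 and compound 2 differ from compound 3 in more than one place, so no single step among the measured compounds is isolated.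

Compound 4 `CN(C)CCN1CCN(CC(=O)Nc2ccc(-c3nc4ccccc4o3)cc2)CC1` differs from compound 3 in one place: hydrogen in place of methyl on an aromatic carbon. Compound 4 carries the same chain as compound 1 between the two amines, while compound 2 carries a longer one.

Because compound 1 gives 1790 nM and compound 2 gives 10600 nM, the expectation for compound 4 is a number lying between them, nearer the lower one; the expected step from compound 3 is a 2.2-fold lower number from compound 3 to compound 4 (0.33 log units; beyond the scatter), a modest move toward a lower number that may only just clear the scatter. Compound 4 is therefore expected to give about 6000 nM, within a range from 1800 nM to 20000 nM.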

Compound 4, half-maximal inhibitory concentration: 5310 nM
Estimate against measurement, compound 4: 1.1-fold (0.05 log units) above; the measured number falls inside the stated range.
By their numbers in this assay, from the lowest: compound 1; then compounds 4, 2 and 3 (each within the scatter of the next, the first and the last beyond it).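

Replacing methyl with hydrogen on the aromatic carbon ortho to a large group and meta to a 1,3-benzoxazol-2-yl group gives a 2.4-fold lower number from compound 3 to compound 4 (0.39 log units; beyond the scatter) in this assay, so the methyl at this place in compound 3 goes with weaker inhibition. The same exchange at the other place runs the opposite way, with a 3.0-fold higher number from compound 1 to compound 4 (0.47 log units; beyond the scatter) in this assay, so among these compounds the direction of the step depends on where the methyl sits. The change in chain length gives a 2.0-fold lower number from compound 2 to compound 4 (0.30 log units; within the scatter), which does not tell those two compounds apart.

Nothing on hand explains why the two methyl steps run in opposite directions. Going by these compounds, whether an ethyl, a methoxy or a chlorine on the same aromatic carbon would follow the methyl remains open, as does the effect of a still longer chain between the two amines.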